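The source may report more compounds than this note shows. Statements on the series, on what has been measured and on what is new or still open speak of the compounds shown alone.

Measured compounds:
- compound 1, `COc1ccc(N)c(C(=O)CCNC(=O)C2CC2)c1`, a functional assay for inhibition of kynurenine 3-monooxygenase (Rattus norvegicus), tested at 1 mM; a lower number here means less inhibition, a higher number more inhibition at the concentration tested (going by the name of the read-out): 99.9%
- compound 2, `Nc1ccc(Cl)cc1C(=O)CCNC(=O)C1CC1`, this assay: "not determined" (no result reported)
- compound 3, `CC(=O)NCCC(=O)c1cc(Cl)ccc1N`, this assay: "not determined" (no result reported)

Three compounds share the core of compound 1, but only compound 1 carries a number. In this assay compound 1 gives 99.9%, which is a high number at the tested concentration. Compound 2 and compound 3 have no result reported in this assay, so nothing can be read from them about the effect of the chloro substituent or of the acetyl group on the amide nitrogen. For the measured compounds named here, compound 1 therefore stands alone as the reference; no step between measured compounds is available.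

The next compound, compound 4, `COc1ccc(N)c(C(=O)CCNC(=O)C2CCCC2)c1`, differs from compound 1 in one place: cyclopentyl in place of cyclopropyl on a carbonyl carbon. The change enlarges the ring on the carbonyl carbon from three to five carbons while leaving the rest of the molecule untouched.

With compound 1 already at the top of the scale, there is no room for an upward step. The expectation is that the number of compound 4 stays high, with the step estimated at a number 4.9 percentage points lower from compound 1 to compound 4 (within the scatter), that is, none beyond the scatter or at most a small decrease. Compound 4 is thus expected to give about 95% in this assay, within a range from 80% to 100%.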

Compound 4, a percentage reported as inhibition, at one concentration (the size of the read-out at that concentration, not a potency): 96.3%
Compound 4: middle estimate off by 1.3 percentage points, on the low side, within the range that was stated.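

For the compounds shown here, compound 4 gives the first reading at this position: with cyclopentyl in place of cyclopropyl on a carbonyl carbon, the result is a number 3.6 percentage points lower from compound 1 to compound 4 (within the scatter) in this assay. A three-membered ring on this carbonyl is therefore not required for a high number in this assay, as the five-membered ring serves as well in this pair, while the methoxy-bearing remainder of the molecule stays unchanged. No measurement is available that accounts for this outcome at this position.

With compound 1 at 99.9% and compound 4 at 96.3%, a percentage read at a single concentration does not separate the two rings, so any difference in potency between them remains unresolved. Also open, going by these compounds, is how this carbonyl position responds to a phenyl ring, a longer open chain such as n-hexyl, or a ring carrying a carboxylic acid or an amine, and whether the same reading would hold with chloro on the shared core in place of methoxy.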